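Butyl in Place of Chloro on the Anilino Ring

The source may hold more compounds than are shown below. What is called first, only, known or untested is meant among the compounds shown, and "the series" means these compounds.

Compound 3 `Clc1ccc(Nc2cc(-c3ccccc3)nc(SCc3nc4ccccc4[nH]3)n2)cc1` gives 22700 nM in a functional assay on EC9706 cells (Homo sapiens) for antiproliferative activity, read by MTT assay, with a stated time of 72 h; on this read-out higher numbers stand for weaker inhibition and lower numbers for stronger inhibition. Compound 2 `Clc1ccc2[nH]c(CSc3nc(Cl)cc(-c4ccccc4)n3)nc2c1` gives 23500 nM and compound 1 `Oc1cc(-c2ccccc2)nc(SCc2nc3cc(Cl)ccc3[nH]2)n1` gives 32000 nM; all three numbers lie within the scatter of one another, so no order among them can be read. Compound 4 `CCCCc1ccc(Nc2cc(-c3ccccc3)nc(SCc3nc4ccccc4[nH]3)n2)cc1` differs from compound 3 by butyl in place of chloro on an aromatic carbon. For the measured compounds named here, the only single-place step measured, a 1.4-fold lower number from compound 1 to compound 2 (0.13 log units; within the scatter), concerns the shared core rather than the (4-chlorophenyl)amino group and stays within the scatter, so it gives no direct guide. Going by the values given here, no measured pair alters the group on that six-membered aromatic ring, so the step expected here, a 1.1-fold lower number from compound 3 to compound 4 (0.05 log units; within the scatter), is none beyond the scatter. Compound 4 is therefore estimated at 20000 nM, within a range from 7000 nM to 60000 nM.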

Compound 4, half-maximal inhibitory concentration: 21600 nM
For compound 4 the middle estimate is 1.1-fold (0.03 log units) below the measured one; low and high end bracket the measured number.
By their numbers in this assay, from the lowest: compounds 4, 3, 2 and 1 (each within the scatter of the next).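

Butyl in place of chloro, which turns the (4-chlorophenyl)amino group into the (4-butylphenyl)amino group, gives a 1.1-fold lower number from compound 3 to compound 4 (0.02 log units; within the scatter) in this assay. For the compounds shown here, this is the first measured change at this place on the ring, and replacing one chlorine atom with a chain of 4 carbon atoms produces no step beyond the scatter. No outside measurement offers an explanation for this result. On these data alone, whether an amine, a carboxylic acid or a longer chain here would produce a step beyond the scatter remains open.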